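A few compounds are considered here, and "the series" means these few. Any claim that something is new, unique, unknown or untested is made for them only; others in the source may bear on it.

In a functional assay on SK-MEL-28 cells (Homo sapiens) for inhibition, read by MTT assay, with a stated time of 48 h (on this read-out higher numbers stand for weaker inhibition and lower numbers for stronger inhibition), compound 2 (`O=C1N/C(=N\Cc2ccccc2Cl)S/C1=C1/CCNC(=O)c2[nH]ccc21`) gives > 100000 nM, which is a limit of the assay and not a number. Compound 1 (`O=C1N/C(=N\Cc2ccc(Cl)cc2)S/C1=C1/CCNC(=O)c2[nH]ccc21`) gives > 100000 nM, again a limit. The whole picture so far is the limit of > 100000 nM in this assay, at which 2 of the 2 values shown sit. Compound 3 (`Cc1ccc(C/N=C2\NC(=O)/C(=C3\CCNC(=O)c4[nH]ccc43)S2)cc1`) differs from compound 2 as follows: 4-methylphenyl in place of 2-chlorophenyl on a saturated chain carbon bound to a double-bonded nitrogen. In short, 4-methylphenyl stands in place of 2-chlorophenyl on a saturated chain carbon bound to a double-bonded nitrogen. Among the measured compounds shown here, the only measured step that bears on this change is a step that the two limits leave unreadable from compound 1 to compound 2, and it offers no size to carry over. No step in either direction beyond the usual scatter is therefore expected in this assay, and the expected step is a number no higher from compound 2 to compound 3 (the limit leaves the size open). For compound 3 the estimated value is 100000 nM, with an expected range from 30000 nM to 200000 nM.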

Compound 3, half-maximal inhibitory concentration: 4150 nM
Estimate against measurement, compound 3: 24-fold (1.38 log units) above, outside the stated range (below it).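

In this assay, the place on a saturated chain carbon bound to a double-bonded nitrogen now shows that it can move the read-out, which the earlier pair could not show because their step cannot be read: putting 4-methylphenyl in place of 2-chlorophenyl gives an at least 24-fold lower number from compound 2 to compound 3 (1.38 log units; beyond the scatter). Methyl in place of chloro on an aromatic carbon, the only difference between 4-chlorophenyl and 4-methylphenyl, gives an at least 24-fold lower number from compound 1 to compound 3 (1.38 log units; beyond the scatter), so this single exchange is enough to bring a measurable number. Only compound 3 has a value that is a number, and the other two stay at a limit: the limit of > 100000 nM in this assay, at which 2 of the 3 values shown sit.

On these data alone, the full size of both steps stays open, since each starts from a limit. Also open, as far as these compounds go, is how a methoxy group, an amine or a carboxylic acid would read in place of the methyl of compound 3.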